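Moving the fluorine once more on a fluorobenzyl group

The compounds below may be only part of what the source reports. "The series", "measured", "known", "first", "only" and "open" are said of these compounds alone.

- compound 1 `OC[C@H]1O[C@@H](n2cnc3c(NCc4ccccc4F)ncnc32)[C@H](O)[C@@H]1O`: 3200 nM
- compound 2 `OC[C@H]1O[C@@H](n2cnc3c(NCc4cccc(F)c4)ncnc32)[C@H](O)[C@@H]1O`: 920 nM

Both values come from a functional assay on HL-60 cells (Homo sapiens) for antiproliferative activity, with a stated time of 72 h; on this read-out higher numbers stand for weaker inhibition and lower numbers for stronger inhibition. Compound 2 holds the lower of the two numbers, and the gap to compound 1 lies beyond the usual scatter. The next compound, compound 3 `OC[C@H]1O[C@@H](n2cnc3c(NCc4ccc(F)cc4)ncnc32)[C@H](O)[C@@H]1O`, keeps the shared core and differs from compound 2 in one group: 4-fluorophenyl in place of 3-fluorophenyl on a saturated chain carbon bound to a nitrogen on an aromatic ring. Put simply, 4-fluorophenyl takes the place of 3-fluorophenyl on a saturated chain carbon bound to a nitrogen on an aromatic ring.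

Within the data shown here, one measured step bears on this change: a 3.5-fold lower number from compound 1 to compound 2 (0.54 log units; beyond the scatter). That modest step also exchanged one fluorophenyl group for another, so such an exchange can move the number beyond the scatter. It cannot show which way the next exchange will go. Among the measured compounds shown here, with compound 2 at 920 nM, the lower number so far, a modest rise is expected rather than a further fall. The estimated step is a 1.6-fold higher number from compound 2 to compound 3 (0.21 log units; within the scatter). In this assay the estimate for compound 3 is 1500 nM, with an expected range from 500 nM to 4500 nM.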

Compound 3, half-maximal inhibitory concentration: 1200 nM
The estimate for compound 3 lay 1.3-fold (0.10 log units) above the measured number; the range from low to high includes it.
By their numbers in this assay, from the lowest: compounds 2 and 3 (each within the scatter of the next); then compound 1.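

Measured in this assay, the exchange of 3-fluorophenyl for 4-fluorophenyl gives a 1.3-fold higher number from compound 2 to compound 3 (0.12 log units; within the scatter), so these two placements of the fluorine cannot be told apart on this read-out. The exchange of 2-fluorophenyl for 4-fluorophenyl gives a 2.7-fold lower number from compound 1 to compound 3 (0.43 log units; beyond the scatter), which means that both exchanges away from 2-fluorophenyl now end beyond the scatter, and among these three compounds only the 2-fluorophenyl group stands apart, with the higher number. No other measurement accompanies these numbers to explain that difference.

The three compounds leave open whether fluorine itself matters or whether any group in these places on the ring would give the same picture, a question that a plain phenyl, a chlorophenyl or a methoxyphenyl on the same saturated chain carbon would help to answer. On these data alone, it also remains open whether the 3-fluorobenzyl and 4-fluorobenzyl compounds would stay this close, and the 2-fluorobenzyl compound apart from them, in cells other than the ones used here.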